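Aryl swap on the piperazine nitrogen: from chloro to hydroxy

The source may hold more compounds than are shown below. What is called first, only, known or untested is meant among the compounds shown, and "the series" means these compounds.

Measured so far:
compound 1 `COCC1=C(C(=O)OC)C(c2cc(F)c(F)cc2F)N(C(=O)NCCCN2CCN(c3ccccc3C(N)=O)CC2)C(=O)N1` — 0.1 nM
compound 2 `COC(=O)C1=C(C)NC(=O)N(C(=O)NCCCN2CCN(c3ccc(Cl)cc3)CC2)C1c1ccc(F)c(F)c1` — 0.8 nM
compound 3 `COC(=O)C1=C(C)NC(=O)N(C(=O)NCCCN2CCN(c3cccc(Cl)c3)CC2)C1c1ccc(F)c(F)c1` — 0.7 nM

In an assay on liver for binding affinity to Alpha-1A adrenergic receptor (Homo sapiens), using microsomes (on this read-out lower numbers stand for stronger inhibition and higher numbers for weaker inhibition), compound 2 gives 0.8 nM, the highest of the three numbers. Compound 3 sits within the scatter of it, a 1.1-fold lower number from compound 2 to compound 3 (0.06 log units; within the scatter). Compound 1 gives 0.1 nM, a lower number beyond the scatter, but its structure differs from compound 2 in more than one place, so no single step can be read from that pair.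

Compound 4 `COC(=O)C1=C(C)NC(=O)N(C(=O)NCCCN2CCN(c3ccccc3O)CC2)C1c1ccc(F)c(F)c1` is the next member. It differs from compound 2 as follows: 2-hydroxyphenyl in place of 4-chlorophenyl on an amine nitrogen in a ring.

Among the compounds with values here, the only measured step on the same ring nitrogen is the one from compound 2 to compound 3, which stays within the scatter. That step moves a chlorine around the ring; the step to compound 4 instead brings in a hydroxyl, and nothing measured covers such a change. The expectation is therefore a step of modest size at most, with no firm direction, a 1.3-fold lower number from compound 2 to compound 4 (0.12 log units; within the scatter). Compound 4 is estimated at 0.6 nM, with a range from 0.2 nM to 2 nM.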

Compound 4, inhibition constant: 0.6 nM
For compound 4 middle estimate and measured number coincide at the digits printed; the measured number falls inside the stated range.
By their numbers in this assay, from the lowest: compound 1; then compounds 4, 3 and 2 (each within the scatter of the next).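

Exchanging a chlorophenyl for 2-hydroxyphenyl on the amine nitrogen in the ring removes chlorine and adds a hydrogen-bond donor and acceptor, yet in this assay both steps stay within the scatter (a 1.3-fold lower number from compound 2 to compound 4 (0.12 log units; within the scatter); a 1.2-fold lower number from compound 3 to compound 4 (0.07 log units; within the scatter)). The earlier step only moved chlorine around the aryl ring, whereas these steps show that a change in substituent and in its ring position together still leaves compounds 2, 3 and 4 indistinguishable on this read-out. No measurement at hand speaks to what underlies this result.

From the compounds shown here alone, whether the same holds for a methoxy group or a carboxylic acid in place of the hydroxyl, or for an unsubstituted phenyl, remains open. The lower number of compound 1 cannot be assigned to its aryl group, since its structure differs from these compounds in more than one place.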